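Benzylamine series: from dichloro to dimethoxy

This account rests on a few compounds, and the source may have more. Where it says the series, first, only, none or still open, it means among the compounds named here.

Notes on three compounds sharing one core. Compound 1 `Nc1cc(N)c2nc(-c3ccccc3)c(Oc3ccc(Cl)c(Cl)c3)nc2c1` carries a 3,4-dichlorophenyl ether; in a functional assay on SK-MEL-2 cells (Homo sapiens) for inhibition, read by sulforhodamine B assay, with a stated time of 48 h (on this read-out lower numbers stand for higher toxicity in this test and higher numbers for lower toxicity in this test), compound 1 gives 89100 nM. Compound 3 `Nc1cc(N)c2nc(-c3ccccc3)c(NCc3ccc(Cl)c(Cl)c3)nc2c1` carries the same aryl group through a saturated chain carbon bound to a nitrogen on the aromatic ring, and in this assay compound 3 gives 9550 nM, the lowest of the two numbers, with compound 1 the nearest neighbour beyond the scatter. For compound 2 `CCOC(=O)[C@H](CCC(=O)O)NC(=O)c1ccc(CNc2nc3cc(N)cc(N)c3nc2-c2ccccc2)cc1` this assay reports only a limit, < 100000 nM (the limit of < 100000 nM in this assay, at which 1 of the 3 values shown sits). Compound 4 `COc1ccc(CNc2nc3cc(N)cc(N)c3nc2-c2ccccc2)cc1OC` is the next step: 3,4-dimethoxyphenyl in place of 3,4-dichlorophenyl on a saturated chain carbon bound to a nitrogen on an aromatic ring. Among the compounds with values here, no measured pair covers this swap, so a modest weakening is expected, a 2.1-fold higher number from compound 3 to compound 4 (0.32 log units; beyond the scatter), with compound 4 estimated at 20000 nM (6000 nM to 60000 nM).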

Compound 4, concentration lethal to 50% of the cells: < 100000 nM
Compound 4 ended at the assay's limit; the forecaster's own chance of this, stated with the estimate: 15%; the middle value lies beyond the limit too.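

In this assay, within the data shown here, compound 4 gives < 100000 nM as a limit and not a number, and no step from compound 3 to compound 4 can be read. The compounds shown leave open how far 3,4-dimethoxyphenyl in place of 3,4-dichlorophenyl shifts this read-out.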